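Bulkier alkyl on the core of compound 3

A few compounds are considered here, and "the series" means these few. Any claim that something is new, unique, unknown or untested is made for them only; others in the source may bear on it.

Measured so far:
compound 1 `CS(=O)(=O)N1CCN(CC(O)CN2CCC(CNC(=O)c3cccc4[nH]cnc34)CC2)CC1`, 6.31 nM
compound 2 `CS(=O)(=O)N1CCN(CC(O)CN2CCC(NC(=O)c3cccc4[nH]cnc34)CC2)CC1`, 251 nM
compound 3 `CCc1nc2c(C(=O)NCC3CCN(CC(O)CN4CCN(S(C)(=O)=O)CC4)CC3)cccc2[nH]1`, 0.501 nM

In an assay on isolated protein for binding affinity to 5-hydroxytryptamine receptor 4 (Homo sapiens) (on this read-out higher numbers stand for weaker inhibition and lower numbers for stronger inhibition), compound 3 stands lowest of the three numbers. Its nearest neighbour is compound 1, which differs only by carrying hydrogen where compound 3 carries ethyl; this step, a 13-fold lower number from compound 1 to compound 3 (1.10 log units; beyond the scatter), is a large one. Compound 2, which has the same core as compound 1 but a shorter linker to the ring, gives the highest number of the three, far beyond the scatter from compound 3.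

Compound 4 `CC(C)(C)c1nc2c(C(=O)NCC3CCN(CC(O)CN4CCN(S(C)(=O)=O)CC4)CC3)cccc2[nH]1` is the next candidate. It differs from compound 3 by tert-butyl in place of ethyl on an aromatic carbon. Among the measured compounds shown here, the only measured step that bears on this position is the one from hydrogen to ethyl, where adding a small alkyl group lowered the number strongly. Whether a still larger alkyl group carries the trend further, holds it, or reverses it cannot be told from these three compounds; the step from compound 1 to compound 3 points towards alkyl being tolerated or favoured, but it says nothing about bulk beyond ethyl.

The step from compound 3 to compound 4 is therefore expected to be small, a 1.6-fold higher number from compound 3 to compound 4 (0.20 log units; within the scatter), with the direction uncertain. For compound 4 the estimated value in this assay is 0.8 nM, expected to lie between 0.2 nM and 4 nM.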

Compound 4, inhibition constant: 12.6 nM
Beside the measured number, compound 4's estimate is 16-fold (1.20 log units) below it, and the stated range ends below it.
By their numbers in this assay, from the lowest: compound 3; then compounds 1 and 4 (each within the scatter of the next); then compound 2.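

In this assay, this place on the five-membered aromatic ring, between two ring nitrogen atoms, proves sensitive to the size of its alkyl group: tert-butyl in place of ethyl gives a large step the other way (a 25-fold higher number from compound 3 to compound 4 (1.40 log units; beyond the scatter)), wiping out the gain seen when ethyl replaced hydrogen (a 13-fold lower number from compound 1 to compound 3 (1.10 log units; beyond the scatter)). Compared with the hydrogen compound, the tert-butyl compound lies within the scatter (a 2.0-fold higher number from compound 1 to compound 4 (0.30 log units; within the scatter)), so the trend does not run steadily with the number of carbon atoms: of these three groups ethyl gives the lowest number, while hydrogen and tert-butyl cannot be told apart. The data shown offer no explanation for this reversal.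

The compounds shown leave open how the number changes for groups of intermediate size or shape, such as propyl, isopropyl or cyclopropyl, and so where between ethyl and tert-butyl the gain is lost. They also leave open whether a group carrying oxygen or nitrogen at this place, such as methoxymethyl or aminomethyl, would behave like ethyl, and whether ethyl would give a similar gain on the shorter linker of compound 2.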